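The source may hold more compounds than are shown below. What is called first, only, known or untested is meant among the compounds shown, and "the series" means these compounds.

Of the compounds shown here, two on the shared core have been measured so far. Compound 1 `Nc1scc(-c2cccc(F)c2)c1C(=O)c1ccccc1` gives 51% in a functional assay on CHO cells for agonist activity at adenosine receptor A1 (Homo sapiens), read by fluorescence and ERK phosphorylation, with stated times of 30 min and 1.5 h, tested at 3 uM; a higher number here means a stronger effect of the compound at the concentration tested, a lower number a weaker effect. Compound 2 `Nc1scc(-c2ccc(Cl)cc2)c1C(=O)c1ccccc1` gives 46% in this assay. Going by the values given here, the single measured step, a number 5 percentage points lower from compound 1 to compound 2 (within the scatter), exchanges one halogen-bearing phenyl for another and moves nothing beyond the scatter. Of the two numbers shown, compound 2 and compound 1 sit within the scatter of each other, so neither can be placed above the other.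

Compound 3 `Nc1scc(-c2ccc(Br)cc2)c1C(=O)c1ccccc1` is not yet measured. Its change from compound 2 is bromo in place of chloro on an aromatic carbon. Among the compounds with values here, the only step that bears on it is the phenyl exchange between compound 1 and compound 2, which left the read-out essentially flat. The expected step is therefore no change at the digits printed from compound 2 to compound 3 (within the scatter), nothing beyond the scatter. Compound 3 is estimated at 46%, with a range from 30% to 62%.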

Compound 3, a percentage reported as activity, at one concentration (the size of the read-out at that concentration, not a potency): 46%
Compound 3: middle estimate and measured number agree at the digits printed; the range from low to high includes it.
By their numbers in this assay, from the lowest: compounds 2, 3 and 1 (each within the scatter of the next).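

In this assay, the exchange of one halogen alone, with the 4-substituted phenyl otherwise kept, gives no change at the digits printed from compound 2 to compound 3 (within the scatter), so at this place, para to a large group, chloro and bromo cannot be told apart. The wider exchange gives a number 5 percentage points lower from compound 1 to compound 3 (within the scatter), so 4-bromophenyl, like 4-chlorophenyl before it, cannot be separated from 3-fluorophenyl. No measurement bears on why the read-out stays flat across these changes.

Every substituent shown on this phenyl is a halogen, so it remains open whether an amine, a carboxylic acid or a methoxy group at the same place would move the read-out beyond the scatter. Each number is also the size of the effect at one concentration, which leaves potency across the series open.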